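This account rests on a few compounds, and the source may have more. Where it says the series, first, only, none or still open, it means among the compounds named here.

Series notes. In an assay on isolated protein for inhibition of Rho-associated protein kinase 2 (Homo sapiens), read by scintillation counting, radiometric assay and 33P incorporation, with a stated time of 40 min, in the presence of a further agent that is not named here (a higher number here means a weaker inhibitor, a lower number a stronger inhibitor), compound 1 `Cc1ccc(C(=O)Nc2cccc(NC(=O)COc3ccc4c(=O)ccoc4c3)c2)cc1` gives 22 nM, compound 2 `CCc1ccc(C(=O)Nc2cccc(NC(=O)COc3ccc4c(=O)ccoc4c3)c2)cc1` gives 24 nM, and compound 3 `CCCc1ccc(C(=O)Nc2cccc(NC(=O)COc3ccc4c(=O)ccoc4c3)c2)cc1` gives 14 nM. Compound 3 sits within the scatter of both other compounds: a 1.6-fold lower number from compound 1 to compound 3 (0.20 log units; within the scatter) and a 1.7-fold lower number from compound 2 to compound 3 (0.23 log units; within the scatter), and likewise a 1.1-fold higher number from compound 1 to compound 2 (0.04 log units; within the scatter). The next step leads to compound 4 `CC(C)(C)c1ccc(C(=O)Nc2cccc(NC(=O)COc3ccc4c(=O)ccoc4c3)c2)cc1`: tert-butyl in place of propyl on an aromatic carbon, the place being para to a large group, so that 4-propylphenyl becomes 4-(tert-butyl)phenyl. For the measured compounds named here, the three measured steps each lengthen the same chain by one carbon, and none moved this assay beyond the scatter; no measured step covers branching of the chain. On that basis the step of a 1.1-fold higher number from compound 3 to compound 4 (0.06 log units; within the scatter) is expected to stay within the scatter. Compound 4 is therefore estimated at 16 nM in this assay, with a range from 6 nM to 45 nM.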

Compound 4, half-maximal inhibitory concentration: 34 nM
The estimate for compound 4 lay 2.1-fold (0.33 log units) below the measured number, and the stated range covers the measured number.
By their numbers in this assay, from the lowest: compounds 3, 1, 2 and 4 (each within the scatter of the next, the first and the last beyond it).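

For the compounds shown here, replacing propyl with tert-butyl on this aromatic carbon gives the only step that lies beyond the scatter in this assay (a 2.4-fold higher number from compound 3 to compound 4 (0.39 log units; beyond the scatter)), while every step between the straight chains stays within it. The same tert-butyl group stays within the scatter against the two shorter chains (a 1.4-fold higher number from compound 2 to compound 4 (0.15 log units; within the scatter); a 1.5-fold higher number from compound 1 to compound 4 (0.19 log units; within the scatter)), so the branched chain separates from propyl alone. No available evidence bears on this step.

Open, as far as these compounds go, is how isopropyl, cyclopropyl or a longer chain such as butyl would read at this position. Also open, from the compounds shown here alone, is how an amine or a carboxylic acid would read there.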